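The source may report more compounds than this note shows. Statements on the series, on what has been measured and on what is new or still open speak of the compounds shown alone.

Measured compounds:
- compound 1 `O=C1Nc2cccc(Cl)c2/C1=N/NC(=S)N1CCN(c2ccccc2)CC1` — in a functional assay on MCF7 cells (Homo sapiens) for inhibition, read by MTT assay, with a stated time of 72 h (a lower number here means a stronger inhibitor, a higher number a weaker inhibitor), compound 1 gives 52100 nM
- compound 2 `O=C1Nc2ccc(Cl)cc2/C1=N/NC(=S)N1CCN(c2ccc(Cl)cc2)CC1` — in this assay compound 2 gives 13100 nM
- compound 3 `O=C1Nc2ccccc2/C1=N/NC(=S)Nc1ccccc1` — in this assay compound 3 gives > 100000 nM

Compound 1 and compound 2 carry a chloro on the shared core and give numbers in this assay. Compound 3, lacking any chloro on the core, reaches only a limit in this assay, and > 100000 nM is therefore a limit of the assay rather than a number. Among the three values shown, one sits at that limit (the limit of > 100000 nM in this assay, at which 1 of the 3 values shown sits).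

Compound 4 `O=C1Nc2ccc(Cl)cc2/C1=N/NC(=S)Nc1ccccc1` has not yet been measured; it differs from compound 3 by chloro in place of hydrogen on an aromatic carbon. For the measured compounds named here, no step between two measured compounds differing in a single place exists in this set, so the size of this change rests on the spread of the measured values alone. Compound 2 shares the chloro-bearing core of compound 4 and gives a number in this assay, whereas compound 3 does not. The expectation is a move toward stronger inhibition from compound 3 to compound 4 an at least 1.6-fold lower number from compound 3 to compound 4 (0.22 log units; that floor lies within the scatter), though compound 3 stands at a limit, so its size is open. In this assay compound 4 is expected near 60000 nM, within 15000 nM to 200000 nM, with a real chance that only a limit is reported.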

Compound 4, half-maximal inhibitory concentration: 35000 nM
The estimate for compound 4 lay 1.7-fold (0.23 log units) above the measured number; the measured number falls inside the stated range.
By their numbers in this assay, from the lowest: compound 2; then compounds 4 and 1 (each within the scatter of the next). At a limit, above all of these: compound 3.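

Chloro in place of hydrogen on an aromatic carbon of the shared core, meta to a fused ring and para to a fused ring, gives the first step in this set that differs in one place: an at least 2.8-fold lower number from compound 3 to compound 4 (0.45 log units; beyond the scatter) in this assay. Compounds 1 and 2 also carry chloro on the core but differ from compound 3 in more than one place, so they could not isolate this change. Compound 3 gives > 100000 nM, which is a limit, so the step is only a floor and its full size remains unknown: the limit of > 100000 nM in this assay, at which 1 of the 4 values shown sits.

The compounds shown leave open whether an amine, a methoxy group or bromo at this position would match chloro. They also leave open whether chloro at another carbon of the core would give a similar step.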